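Fluoro for chloro in the 3-chloro-4-fluorophenyl compound

The source may hold more compounds than are shown below. What is called first, only, known or untested is meant among the compounds shown, and "the series" means these compounds.

For the measured compounds named here, in a functional assay on HeLa cells (Homo sapiens) for antiproliferative activity, read by CCK-8 assay, with a stated time of 48 h (a lower number here means a stronger inhibitor, a higher number a weaker inhibitor), compound 1 `Cc1cc(Nc2cc(N3CCN(C)CC3)nc(Nc3ccc(F)cc3)n2)n[nH]1` gives 680 nM and compound 2 `Cc1cc(Nc2cc(N3CCN(C)CC3)nc(Nc3ccc(F)c(Cl)c3)n2)n[nH]1` gives 277 nM, the lower of the two numbers so far. Next is compound 3 `Cc1cc(Nc2cc(N3CCN(C)CC3)nc(Nc3ccc(F)c(F)c3)n2)n[nH]1`, where 3,4-difluorophenyl replaces the 3-chloro-4-fluorophenyl of compound 2: fluoro in place of chloro on an aromatic carbon. This is fluoro in place of chloro on an aromatic carbon, ortho to a fluoro group and meta to a large group. Going by the values given here, one measured step bears on it: a 2.5-fold lower number from compound 1 to compound 2 (0.39 log units; beyond the scatter), modest but beyond the scatter, with chloro in place of hydrogen on an aromatic carbon. Among the compounds with values here, no measured step shows fluoro in place of chloro directly, so the expectation is indirect: part of that step may be given back, as a small rise in this assay. The expected change is a 1.4-fold higher number from compound 2 to compound 3 (0.16 log units; within the scatter). For compound 3 the estimated value is 400 nM, with an expected range of 190 nM to 850 nM.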

Compound 3, half-maximal inhibitory concentration: 438 nM
Compound 3: the middle estimate sits 1.1-fold (0.04 log units) below what was measured; the range from low to high includes it.
By their numbers in this assay, from the lowest: compounds 2, 3 and 1 (each within the scatter of the next, the first and the last beyond it).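

In this assay, fluoro in place of chloro on this aromatic carbon, ortho to a fluoro group and meta to a large group, gives a 1.6-fold higher number from compound 2 to compound 3 (0.20 log units; within the scatter), so the two halogens are not resolved at this position. Fluoro in place of hydrogen gives a 1.6-fold lower number from compound 1 to compound 3 (0.19 log units; within the scatter), also unresolved, so of the three substituents only chloro and hydrogen are separated, by a 2.5-fold lower number from compound 1 to compound 2 (0.39 log units; beyond the scatter), and the fluoro compound sits within the scatter of both. Nothing available explains these values.

Open, on these data alone, is whether a bromo, methyl or methoxy group on this carbon would extend the step seen with chloro or leave the number unchanged. Also open, as far as these compounds go, is whether chloro keeps its step over hydrogen without the 4-fluoro group.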